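The source may hold more compounds than are shown below. What is called first, only, known or untested is meant among the compounds shown, and "the series" means these compounds.

Compound 1 `O=C(O)c1csc(SCCN2C(=O)CC[C@@H]2/C=C/[C@@H](O)Cc2cccc(-c3ccccc3)c2)n1` carries a phenyl group on its core, and in an assay on CHO cells for displacement of a labelled ligand from prostaglandin E2 receptor EP3 subtype (Mus musculus), read by scintillation counting, with a stated time of 60 min (a lower number here means a stronger inhibitor, a higher number a weaker inhibitor), compound 1 gives 4300 nM. Compound 2 `O=C(O)c1csc(SCCN2C(=O)CC[C@@H]2/C=C/[C@@H](O)Cc2cccc(-c3nc4ccccc4o3)c2)n1` has a 1,3-benzoxazol-2-yl in place of that phenyl. In this assay compound 2 reaches only > 10000 nM, which is a limit of the assay rather than a measured number (the limit of > 10000 nM in this assay, at which 1 of the 2 values shown sits). The step of an at least 2.3-fold higher number from compound 1 to compound 2 (0.36 log units; beyond the scatter) thus counts as a weakening of binding. Compound 3 `Cc1ccc2oc(-c3cccc(C[C@H](O)/C=C/[C@H]4CCC(=O)N4CCSc4nc(C(=O)O)cs4)c3)nc2c1` differs from compound 2 by methyl in place of hydrogen on an aromatic carbon. Among the measured compounds shown here, no measured step shows what a methyl group does at this place; the only measured step, an at least 2.3-fold higher number from compound 1 to compound 2 (0.36 log units; beyond the scatter), concerns a different change and gives no guide. On that basis no step beyond the scatter is expected, and a step that the limit leaves unreadable from compound 2 to compound 3 is expected to be small. Compound 3 is therefore estimated at 15000 nM in this assay, within 5000 nM to 50000 nM, most likely reported again only as a limit.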

Compound 3, inhibition constant: > 10000 nM
Compound 3: only a limit was reported; the forecaster's own chance of this, stated with the estimate: 70%; the middle value lies beyond the limit too.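

With the 5-methyl-1,3-benzoxazol-2-yl group in place of the phenyl, the result is an at least 2.3-fold higher number from compound 1 to compound 3 (0.36 log units; beyond the scatter), so adding a methyl group to the 1,3-benzoxazol-2-yl group does not bring the value back within the measured range. In this assay compound 3 gives > 10000 nM, which is a limit and not a number. The step for the methyl group itself cannot be read, so any gain or loss in binding from this change stays hidden: the limit of > 10000 nM in this assay, at which 2 of the 3 values shown sit.

On these data alone, how weak compound 2 and compound 3 really are remains open, as does the effect of the methyl group on binding. Also open, as far as these compounds go, is whether a pyridine ring or a methoxy group on the phenyl of compound 1 would give a number that can be read against compound 1.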